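A few compounds are considered here, and "the series" means these few. Any claim that something is new, unique, unknown or untested is made for them only; others in the source may bear on it.

Measured compounds in a functional assay on Ehrlich cells (Mus musculus) for cytotoxicity, read by trypan blue exclusion, with a stated time of 48 h; on this read-out higher numbers stand for weaker inhibition and lower numbers for stronger inhibition:

Compound 1 `O=C(COc1ccccc1)Nc1nc(-c2ccc(Br)cc2)cs1` gives 37100 nM.
Compound 2 `Cc1ccccc1OCC(=O)Nc1nc(-c2ccc(Br)cc2)cs1` gives 44500 nM.
Compound 3 `O=C(COc1ccccc1)Nc1nc(-c2ccc(Cl)cc2)cs1` gives 56800 nM.

All three values sit close together, and none of the steps between them leaves the usual scatter. Compound 1 and compound 3 share everything except the group on the six-membered ring of carbon only that carries the halogen: the difference is chloro in place of bromo on an aromatic carbon, and in this assay it produces a 1.5-fold higher number from compound 1 to compound 3 (0.18 log units; within the scatter). Compound 1 and compound 2 differ by methyl in place of hydrogen on an aromatic carbon, and this step reads a 1.2-fold higher number from compound 1 to compound 2 (0.08 log units; within the scatter). Compound 2 and compound 3 have no single-point relation to each other; their values merely lie within the scatter of one another.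

Compound 4 `Cc1ccccc1OCC(=O)Nc1nc(-c2ccc(Cl)cc2)cs1` has not yet been measured. It stands to compound 3 as compound 2 stands to compound 1: the difference is methyl in place of hydrogen on an aromatic carbon. The place of the change is described in the same words for both pairs, so this is the same change on the other core.

Given that the earlier instance of this change, a 1.2-fold higher number from compound 1 to compound 2 (0.08 log units; within the scatter), stayed within the scatter, the expectation for compound 4 in this assay is a similarly small step, a 1.1-fold higher number from compound 3 to compound 4 (0.06 log units; within the scatter), from compound 3. Compound 4 is therefore estimated at 65000 nM, with a plausible range from 35000 nM to 120000 nM, resting on a single prior example only.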

Compound 4, half-maximal inhibitory concentration: 63100 nM
The estimate for compound 4 lay 1.0-fold (0.01 log units) above the measured number; the measured number falls inside the stated range.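

In this assay the change from phenoxy to 2-methylphenoxy on the chloro compound reads a 1.1-fold higher number from compound 3 to compound 4 (0.05 log units; within the scatter) and matches its earlier instance on the bromo compounds: the same change on two cores in this assay, a 1.2-fold higher number (0.08 log units; within the scatter) from compound 1 to compound 2 and a 1.1-fold higher number (0.05 log units; within the scatter) from compound 3 to compound 4, 1.1-fold (0.03 log units) apart, within the scatter of two such steps. The change of bromo to chloro on the 2-methylphenoxy compounds reads a 1.4-fold higher number from compound 2 to compound 4 (0.15 log units; within the scatter) and likewise matches its earlier instance: the same change on two cores in this assay, a 1.5-fold higher number (0.18 log units; within the scatter) from compound 1 to compound 3 and a 1.4-fold higher number (0.15 log units; within the scatter) from compound 2 to compound 4, 1.1-fold (0.03 log units) apart, within the scatter of two such steps. Among these compounds, both changes therefore carry from one core to the other without a readable difference, but every step here lies within the scatter, so this shows only that neither change moves the number measurably on these two cores, and not that a change with a real effect would carry across in the same way.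

The compounds shown leave open whether any other replacement moves the number beyond the scatter, such as an amine, a carboxylic acid or a longer chain in place of the methyl, or a fluoro group or a nitrile in place of the halogen. They also leave open whether the amide hydrogen or the carbonyl linking the two halves can be replaced without a readable change.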